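Amide variation on the shared core: furan-2-yl in place of 4-methoxyphenyl

A few compounds are considered here, and "the series" means these few. Any claim that something is new, unique, unknown or untested is made for them only; others in the source may bear on it.

Measured so far in a functional assay on HCT-116 cells (Homo sapiens) for antiproliferative activity, read by MTT assay, with a stated time of 72 h; on this read-out higher numbers stand for weaker inhibition and lower numbers for stronger inhibition:
compound 1 `CCC(=O)N(C)c1ccc2[nH]c(-c3n[nH]c4ccccc34)cc2n1` gives 10800 nM
compound 2 `CN(C(=O)c1ccc(Cl)cc1)c1ccc2[nH]c(-c3n[nH]c4ccccc34)cc2n1` gives 3000 nM
compound 3 `COc1ccc(C(=O)N(C)c2ccc3[nH]c(-c4n[nH]c5ccccc45)cc3n2)cc1` gives 29500 nM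

Compound 3 gives the highest number of the three: a 2.7-fold higher number from compound 1 to compound 3 (0.44 log units; beyond the scatter), and a 9.8-fold higher number from compound 2 to compound 3 (0.99 log units; beyond the scatter). Compound 4 `CN(C(=O)c1ccco1)c1ccc2[nH]c(-c3n[nH]c4ccccc34)cc2n1` differs from compound 3 by furan-2-yl in place of 4-methoxyphenyl on a carbonyl carbon. For the measured compounds named here, no measured step covers furan-2-yl on the carbonyl carbon. The bearing steps are a 2.7-fold higher number from compound 1 to compound 3 (0.44 log units; beyond the scatter) and a 3.6-fold lower number from compound 1 to compound 2 (0.56 log units; beyond the scatter), which show that the group on the carbonyl carbon moves this assay in either direction by modest amounts. Given that compound 3 stands highest, the number for compound 4 is expected to fall somewhat, a step of a 2.5-fold lower number from compound 3 to compound 4 (0.39 log units; beyond the scatter), landing near compound 1. Compound 4 is estimated at 12000 nM, with a range from 4000 nM to 35000 nM.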

Compound 4, half-maximal inhibitory concentration: 30000 nM
For compound 4 the middle estimate is 2.5-fold (0.40 log units) below the measured one; low and high end bracket the measured number.
By their numbers in this assay, from the lowest: compound 2; then compound 1; then compounds 3 and 4 (each within the scatter of the next).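

Furan-2-yl in place of 4-methoxyphenyl on the carbonyl carbon leaves the number unchanged (a 1.0-fold higher number from compound 3 to compound 4 (0.01 log units; within the scatter)), so a five-membered and a six-membered aromatic ring can read alike here. Compound 2 stays clearly apart from the furan-2-yl amide (a 10-fold higher number from compound 2 to compound 4 (1.00 log units; beyond the scatter)), and ethyl does as well (a 2.8-fold higher number from compound 1 to compound 4 (0.44 log units; beyond the scatter)), so of the three aromatic groups shown only 4-chlorophenyl gives a lower number than ethyl. No evidence is available to explain these differences.

Still open, going by these compounds, is how a longer chain in place of ethyl would read, or an amine or a carboxylic acid on the aromatic ring. Also open, on these data alone, is whether bromo or fluoro in place of chloro would keep the lower number of compound 2.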